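The source may report more compounds than this note shows. Statements on the series, on what has been measured and on what is new or still open speak of the compounds shown alone.

Measured compounds in an assay on CHO cells for displacement of a labelled ligand from Substance-P receptor (Homo sapiens), in the presence of a further agent that is not named here; on this read-out higher numbers stand for weaker inhibition and lower numbers for stronger inhibition:
compound 1 `C[C@@H](O[C@H]1CN2C(=O)C=C(c3ccccc3)CC2[C@@H]1c1ccc(F)cc1)c1cc(C(F)(F)F)cc(C(F)(F)F)c1` gives 89.5 nM
compound 2 `COc1cc(C2=CC(=O)N3C[C@H](O[C@H](C)c4cc(C(F)(F)F)cc(C(F)(F)F)c4)[C@@H](c4ccc(F)cc4)C3C2)ccn1` gives 44 nM
compound 3 `C[C@@H](O[C@H]1CN2C(=O)C=C(c3cnn(C)c3)CC2[C@@H]1c1ccc(F)cc1)c1cc(C(F)(F)F)cc(C(F)(F)F)c1` gives 5.4 nM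

Compound 2 stands second highest of the three numbers in this assay. Its nearest neighbour is compound 1, which differs by a 2.0-fold lower number from compound 1 to compound 2 (0.31 log units; beyond the scatter). Its furthest is compound 3, which differs by an 8.1-fold lower number from compound 2 to compound 3 (0.91 log units; beyond the scatter). Between compound 1 and compound 3 the gap is a 17-fold lower number from compound 1 to compound 3 (1.22 log units; beyond the scatter).

Compound 4 `C[C@@H](O[C@H]1CN2C(=O)C=C(C3=CCOCC3)CC2[C@@H]1c1ccc(F)cc1)c1cc(C(F)(F)F)cc(C(F)(F)F)c1` is not yet measured. Relative to compound 2 the change is a group of 6 heavy atoms (5 carbon, 1 oxygen; one six-membered non-aromatic ring with 1 hetero atom) in place of a group of 8 heavy atoms (6 carbon, 1 nitrogen, 1 oxygen; one six-membered aromatic ring with 1 hetero atom), on a double-bonded ring carbon. Within the data shown here, the steps that bear on this are the two exchanges on the same double-bonded ring carbon: from compound 1 to compound 2 (modest) and from compound 2 to compound 3 (modest). Both went to lower numbers as the group on that carbon changed, but neither involved a six-membered non-aromatic ring, so the measured steps give only a loose guide. The group entering in compound 4 is smaller than the one it replaces and carries one hydrogen-bond acceptor, and on the two steps seen a lower number for compound 4 than for compound 2 is expected, with a 2.2-fold lower number from compound 2 to compound 4 (0.34 log units; beyond the scatter) as the estimated step. For compound 4 an estimated value of 20 nM is expected, with a range from 6 nM to 70 nM.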

Compound 4, half-maximal inhibitory concentration: 9.6 nM
Beside the measured number, compound 4's estimate is 2.1-fold (0.32 log units) above it; measured number inside the range.
By their numbers in this assay, from the lowest: compounds 3 and 4 (each within the scatter of the next); then compound 2; then compound 1.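

The step to the non-aromatic ring gives a 4.6-fold lower number from compound 2 to compound 4 (0.66 log units; beyond the scatter) and a 9.3-fold lower number from compound 1 to compound 4 (0.97 log units; beyond the scatter), so among the compounds shown, an aromatic ring on the double-bonded ring carbon is not required for a low number in this assay. Against the 1-methyl-1H-pyrazol-4-yl group the step is a 1.8-fold higher number from compound 3 to compound 4 (0.25 log units; within the scatter), so the two groups cannot be told apart on this read-out. No measurement shown explains these differences.

Open, on these data alone, is the separate contribution of the ring oxygen and of the ring double bond of the entering group, which a cyclohexenyl group, a saturated tetrahydropyran-4-yl group or a piperidine amine on the same carbon would address. Also open, as far as these compounds go, is whether an open-chain ether at this carbon would fit the same trend.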